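The source may hold more compounds than are shown below. What is called first, only, known or untested is meant among the compounds shown, and "the series" means these compounds.

Measured in a functional assay on U-937 cells (Homo sapiens) for cytotoxicity, read by MTT assay, with a stated time of 24 h; on this read-out lower numbers stand for stronger inhibition and higher numbers for weaker inhibition:
- compound 1 `BrCCCOc1c(Br)cc(Br)cc1Oc1ccc(Br)cc1Br`: 30.3 ug/mL
- compound 2 `CCOC(=O)C(C)Oc1c(Br)cc(Br)cc1Oc1ccc(Br)cc1Br`: 39.5 ug/mL
- compound 3 `OCCOc1c(Br)cc(Br)cc1Oc1ccc(Br)cc1Br`: 34.5 ug/mL

Compound 3 lies within the scatter of both other compounds, with a 1.1-fold higher number from compound 1 to compound 3 (0.06 log units; within the scatter) and a 1.1-fold lower number from compound 2 to compound 3 (0.06 log units; within the scatter). The third measured step, a 1.3-fold higher number from compound 1 to compound 2 (0.12 log units; within the scatter), is also within the scatter. All three steps exchange only the group on the same oxygen, so they bear on compound 4 `C#CCOc1c(Br)cc(Br)cc1Oc1ccc(Br)cc1Br`, although none of them introduces a propargyl group. Compound 4 differs from compound 3 by ethynyl in place of hydroxymethyl on a saturated chain carbon bound to an oxygen on an aromatic ring, which turns 2-hydroxyethyl into propargyl. The expected change is therefore none beyond the scatter in this assay. The estimated step is a 1.0-fold lower number from compound 3 to compound 4 (0.02 log units; within the scatter). For compound 4 the estimated value is 33 ug/mL, with an expected range from 18 ug/mL to 55 ug/mL.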

Compound 4, half-maximal inhibitory concentration: 29.5 ug/mL
Compound 4: the middle estimate sits 1.1-fold (0.05 log units) above what was measured, within the range that was stated.
By their numbers in this assay, from the lowest: compounds 4, 1, 3 and 2 (each within the scatter of the next).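

In this assay the propargyl group brings the first triple bond outside aromatic rings onto this oxygen, yet it stays within the scatter of all three earlier groups, with a 1.2-fold lower number from compound 3 to compound 4 (0.07 log units; within the scatter) and a 1.3-fold lower number from compound 2 to compound 4 (0.13 log units; within the scatter) and a 1.0-fold lower number from compound 1 to compound 4 (0.01 log units; within the scatter). Ethynyl in place of hydroxymethyl, which also removes a hydrogen-bond donor and acceptor from this place, therefore shifts the number by no more than the scatter. No evidence is available to account for this. As far as these compounds go, whether an amine, a carboxylic acid or a longer chain on this oxygen would move the number beyond the scatter remains open.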